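A few compounds are considered here, and "the series" means these few. Any claim that something is new, unique, unknown or untested is made for them only; others in the source may bear on it.

Measured in an ADME assay on HEK293 cells (Homo sapiens) for cytotoxicity, with a stated time of 72 h; a higher number here means that more compound is needed for the effect, a lower number that less compound is needed:

- Compound 1 `C=C[C@@](C)(/C=C/c1ccc(OS(=O)(=O)C(F)(F)F)cc1)CCC=C(C)C`: > 36600 nM
- Compound 2 `C=C[C@@](C)(/C=C/c1ccc(O)cc1)CC/C=C/C(=O)OCC`: > 36600 nM
- Compound 3 `C=C[C@@](C)(/C=C/c1ccc(O)c(CO)c1)CCC=C(C)C`: > 36600 nM

All three compounds stand at the same point: the limit of > 36600 nM in this assay, at which 3 of the 3 values shown sit. For compound 3, > 36600 nM is therefore a limit of the assay and not a number.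

Compound 4 `C=C[C@@](C)(/C=C/c1ccc(O)c(C=O)c1)CCC=C(C)C` has not yet been measured. It carries formyl in place of hydroxymethyl on an aromatic carbon, ortho to a hydroxy group (formyl in place of hydroxymethyl on an aromatic carbon). Going by the values given here, no measured pair shows what this change does in this assay. A small shift towards a lower number is expected, and the estimated change is an at least 1.3-fold lower number from compound 3 to compound 4 (0.11 log units; that floor lies within the scatter). The assay may well report only a limit again. For compound 4 the expected value is 28000 nM, with an estimated range of 9000 nM to 45000 nM.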

Compound 4, half-maximal effective concentration: > 36600 nM
Compound 4 gave a limit, no number; the forecaster's own chance of this, stated with the estimate: 55%; middle value at least 1.3-fold (0.11 log units) from the limit.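

Compound 3 and compound 4 both give a limit and not a number, so no step between them can be read: the limit of > 36600 nM in this assay, at which 4 of the 4 values shown sit.

The compounds shown leave open whether formyl and hydroxymethyl differ at all in this assay.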